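From 4-Chlorophenyl to Furan-2-yl in an Antiproliferative Series

A few compounds are considered here, and "the series" means these few. Any claim that something is new, unique, unknown or untested is made for them only; others in the source may bear on it.

In a functional assay on Hep2C cells (Homo sapiens) for antiproliferative activity, read by MTT assay, with a stated time of 24 h (on this read-out lower numbers stand for stronger inhibition and higher numbers for weaker inhibition), compound 1 `Clc1ccc(-c2cc(-c3ccccc3)c3cc(Br)ccc3n2)cc1` gives 269000 nM and compound 2 `COc1ccc2nc(-c3ccccc3)cc(-c3ccccc3)c2c1` gives 496000 nM. These two values lie within the scatter of each other, so the numbers available do not rank them. A third measured entry, compound 3 `COc1cc(-c2cc(-c3ccccc3)c3cc(Br)ccc3n2)cc(OC)c1OC`, stands as "not determined" (no result reported) and adds no number. Compound 1 therefore sits level with the only other figure in the set.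

The next compound, compound 4 `Brc1ccc2nc(-c3ccco3)cc(-c3ccccc3)c2c1`, carries furan-2-yl in place of 4-chlorophenyl on an aromatic carbon, next to the ring nitrogen (furan-2-yl in place of 4-chlorophenyl on an aromatic carbon). For the measured compounds named here, no two measured compounds differ in one place only, so the data give no direct guide to the effect of this change in this assay. The expectation rests on compound 1 at 269000 nM and on the closeness of compound 2 at 496000 nM. The expected step is a 1.2-fold lower number from compound 1 to compound 4 (0.09 log units; within the scatter), which is none beyond the scatter. Compound 4 is estimated at 220000 nM, with an expected range of 70000 nM to 600000 nM.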

Compound 4, half-maximal inhibitory concentration: 102000 nM
Compound 4: middle estimate off by 2.2-fold (0.33 log units), on the high side; measured number inside the range.
By their numbers in this assay, from the lowest: compound 4; then compounds 1 and 2 (each within the scatter of the next).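

In this assay, for the compounds shown here, furan-2-yl in place of 4-chlorophenyl on the aromatic carbon next to the ring nitrogen gives a 2.6-fold lower number from compound 1 to compound 4 (0.42 log units; beyond the scatter), the first step in this set between compounds that differ in one place. It shows that the number responds to the group at this position, by a modest step that lies beyond the scatter. The change swaps a six-membered aromatic ring of carbon only for a five-membered aromatic ring with a hetero atom, but no measurement here shows why the number moves.

As far as these compounds go, whether an amine or a carboxylic acid on this same carbon would give a lower or a higher number remains open. From the compounds shown here alone, it is also open whether furan-2-yl would give a similar step on a core carrying methoxy in place of the bromine of compound 4.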